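The source may hold more compounds than are shown below. What is called first, only, known or untested is meant among the compounds shown, and "the series" means these compounds.

Measured compounds in a functional assay on HCT-116 cells (Homo sapiens) for inhibition, read by MTT assay, with a stated time of 72 h; a higher number here means a weaker inhibitor, a lower number a stronger inhibitor:
compound 1, `O=C1Nc2ccccc2/C1=N/NC(=S)N1CCN(c2ccccc2)CC1`, gives 11100 nM
compound 2, `Cc1ccc2c(c1)/C(=N/NC(=S)N1CCN(c3ccccc3)CC1)C(=O)N2`, gives 9480 nM
compound 3, `O=C1Nc2ccc(Cl)cc2/C1=N/NC(=S)N1CCN(c2ccccc2)CC1`, gives 3490 nM

Compound 3 has the lowest number of the three in this assay: the steps of a 3.2-fold lower number from compound 1 to compound 3 (0.50 log units; beyond the scatter) and a 2.7-fold lower number from compound 2 to compound 3 (0.43 log units; beyond the scatter) are both beyond the scatter, so it stands apart from compounds 1 and 2. Between those two, a 1.2-fold lower number from compound 1 to compound 2 (0.07 log units; within the scatter) is within the scatter.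

Compound 4, `Cc1ccccc1N1CCN(C(=S)N/N=C2\C(=O)Nc3ccc(Cl)cc32)CC1`, differs from compound 3 by methyl in place of hydrogen on an aromatic carbon; cut one bond further out, the change reads phenyl to 2-methylphenyl. Within the data shown here, the only measured step of the same kind, methyl for hydrogen on an aromatic carbon, is a 1.2-fold lower number from compound 1 to compound 2 (0.07 log units; within the scatter), which fell within the scatter, though it sat on the core ring and not on the phenyl. Among the measured compounds shown here, no step on that phenyl is measured. On that basis the step of a 1.0-fold higher number from compound 3 to compound 4 (0.01 log units; within the scatter) is expected to stay within the scatter. For compound 4 the estimate in this assay is 3600 nM, with a range of 1500 nM to 9000 nM.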

Compound 4, half-maximal inhibitory concentration: 4910 nM
Compound 4: middle estimate off by 1.4-fold (0.13 log units), on the low side; the range from low to high includes it.
By their numbers in this assay, from the lowest: compounds 3, 4, 2 and 1 (each within the scatter of the next, the first and the last beyond it).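

In this assay, the first step measured on the phenyl itself, phenyl to 2-methylphenyl on the core of compound 3, is a 1.4-fold higher number from compound 3 to compound 4 (0.15 log units; within the scatter), so a methyl at this place, ortho to a large group, leaves the number within the scatter. The earlier compounds shown here showed this change only on the shared core, not on the phenyl. Methyl in place of hydrogen on an aromatic carbon now reads alike at two places, with neither step beyond the scatter and the gap between them also within it: the same change on two cores in this assay, a 1.2-fold lower number (0.07 log units; within the scatter) from compound 1 to compound 2 and a 1.4-fold higher number (0.15 log units; within the scatter) from compound 3 to compound 4, 1.6-fold (0.22 log units) apart, within the scatter of two such steps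

Still open, as far as these compounds go, is whether this place accepts anything other than a small carbon group, such as a methoxy, an amine, a carboxylic acid or a longer chain. From the compounds shown here alone, the other aromatic carbons of the phenyl also remain open, for methyl and for those same groups.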